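This account rests on a few compounds, and the source may have more. Where it says the series, first, only, none or still open, it means among the compounds named here.

Measured so far in a functional assay on A549 cells (Homo sapiens) for inhibition, read by sulforhodamine B assay, tested at 10 uM; a lower number here means less inhibition of growth, a higher number more inhibition of growth at the concentration tested:
- compound 1 `CC(=O)N1N=C(c2ccc(OCc3cn(Cc4ccc([N+](=O)[O-])cc4)nn3)cc2)CC1c1ccccc1` gives 15%
- compound 2 `COc1cc(C2CC(c3ccc(OCc4cn(Cc5ccc([N+](=O)[O-])cc5)nn4)cc3)=NN2C(C)=O)ccc1Oc1cn(Cc2ccc([N+](=O)[O-])cc2)nn1` gives 29%
- compound 3 `COc1cc(C2CC(c3ccc([N+](=O)[O-])cc3)=NN2C(C)=O)ccc1OCc1cn(Cc2ccc([N+](=O)[O-])cc2)nn1` gives 39%

Compound 3 gives the highest of the three numbers; compound 2 lies within the scatter of it, compound 1 sits beyond the scatter below it. Compound 4 `COc1cc(C2CC(c3ccccc3)=NN2C(C)=O)ccc1OCc1cn(Cc2ccc([N+](=O)[O-])cc2)nn1` has not been measured. It differs from compound 3 by hydrogen in place of nitro on an aromatic carbon, para to a large group. Among the compounds with values here, no pair of measured compounds differs in this one place, so the size of this step is not known. Compound 1, which also carries an unsubstituted phenyl at this position but differs elsewhere too, gives the lowest number. A moderate decrease in this assay is expected, roughly a number 14 percentage points lower from compound 3 to compound 4 (beyond the scatter). Compound 4 is therefore estimated at 25%, in the range 10% to 40%.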

Compound 4, percent growth inhibition at one concentration: 0%
Compound 4: middle estimate off by 25 percentage points, on the high side, outside the stated range (below it).
By their numbers in this assay, from the lowest: compound 4; then compound 1; then compounds 2 and 3 (each within the scatter of the next).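

In this assay, within the data shown here, the 4-nitrophenyl to phenyl change gives the first single-place step, and it is large (a number 39 percentage points lower from compound 3 to compound 4 (beyond the scatter)). At this position the nitro group therefore counts for all of the growth inhibition seen with compound 3 at the concentration tested. No available data account for the size of this step.

From the compounds shown here alone, whether an amine or a nitrile in the same place would keep the inhibition remains open. So does whether the nitro group specifically is needed, or any group other than hydrogen would do.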